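Sugar ring swap on a triazole-linked quinone core

The source may report more compounds than this note shows. Statements on the series, on what has been measured and on what is new or still open speak of the compounds shown alone.

Measured so far:
compound 1 `O=C1c2c[n+]([O-])c3ccccc3c2C(=O)c2c1c1ccccc1n2Cc1cn([C@H]2O[C@H](CO)[C@@H](O)[C@H]2O)nn1` — 1340 nM
compound 2 `CN1CCN(CCCn2c3c(c4ccccc42)C(=O)c2c[n+]([O-])c4ccccc4c2C3=O)CC1` — 560 nM

Of the compounds shown here, two have been tested in a functional assay on SH-SY5Y cells (Homo sapiens) for cytotoxicity, read by MTT assay, with a stated time of 72 h; a lower number here means a stronger inhibitor, a higher number a weaker inhibitor. Compound 1 gives 1340 nM, the higher of the two numbers, so it is the weaker inhibitor here. Among the measured compounds shown here, compound 2 gives 560 nM, a lower number that lies beyond the usual scatter of the assay, and its structure differs from compound 1 in more than one place, so no single step between them is counted.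

Compound 3 `O=C1c2c[n+]([O-])c3ccccc3c2C(=O)c2c1c1ccccc1n2Cc1cn([C@@H]2O[C@H](CO)[C@@H](O)[C@H](O)[C@H]2O)nn1` has not yet been measured. It differs from compound 1 in one place: 3,4,5-trihydroxy-6-(hydroxymethyl)oxan-2-yl in place of 3,4-dihydroxy-5-(hydroxymethyl)oxolan-2-yl on an aromatic nitrogen. The shared core, the triazole and the position on the aromatic nitrogen are unchanged; only the sugar attached there grows from a five-membered to a six-membered ring, adding one carbon and one oxygen and one more hydrogen-bond donor and acceptor.

For the measured compounds named here, no measured pair shows what such a change does in this assay. The expectation is that the step of a 1.1-fold higher number from compound 1 to compound 3 (0.05 log units; within the scatter) stays small, most likely within the scatter, with no clear direction. On that basis compound 3 is estimated at 1500 nM, expected to fall between 600 nM and 4000 nM.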

Compound 3, half-maximal inhibitory concentration: 880 nM
The estimate for compound 3 lay 1.7-fold (0.23 log units) above the measured number, within the range that was stated.
By their numbers in this assay, from the lowest: compounds 2, 3 and 1 (each within the scatter of the next, the first and the last beyond it).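

In this assay, putting 3,4,5-trihydroxy-6-(hydroxymethyl)oxan-2-yl in place of 3,4-dihydroxy-5-(hydroxymethyl)oxolan-2-yl on the aromatic nitrogen gives a 1.5-fold lower number from compound 1 to compound 3 (0.18 log units; within the scatter), so this position tolerates a sugar that goes from a five-membered to a six-membered ring, from 9 to 11 heavy atoms and from 3 to 4 hydrogen-bond donors, with no change that can be told apart from the scatter. Among the compounds shown here, this is the first reading of a single change here, since compound 1 and compound 2 differ in more than one place and their numbers could not isolate the effect of any one group. No separate measurement bears on why the number stays within the scatter after this swap.

The compounds shown place only these two neutral sugars on the triazole, so it remains open whether the position would tolerate a sugar carrying an amine or a carboxylic acid in place of the hydroxymethyl group. A longer chain linking the triazole to the shared core is also untested among them, and it could show whether the sugar's distance from that core matters as little as its ring size.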